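Cytotoxicity of a Bicyclic Nucleoside Before and After an Amine Change

The source may report more compounds than this note shows. Statements on the series, on what has been measured and on what is new or still open speak of the compounds shown alone.

Of the compounds shown here, three have been tested in a functional assay on MT4 cells (Homo sapiens); a lower number here means that less compound is tolerated, a higher number that more compound is tolerated. Compound 1 `Cc1cn([C@@H]2O[C@H](CO[Si](C)(C)C(C)(C)C)[C@@]3(OS(=O)(=O)C=C3NCCC(=O)O)[C@H]2O[Si](C)(C)C(C)(C)C)c(=O)n(C)c1=O` gives 11500 nM, the lowest of the two numbers recorded, so it is the least tolerated; the nearest is compound 3 `Cc1cn([C@@H]2O[C@@H]3COC4(O)CS(=O)(=O)O[C@@]34[C@H]2O)c(=O)[nH]c1=O`, which gives 100000 nM, a gap beyond the usual scatter. Compound 2 `Cc1cn([C@@H]2O[C@@H]3COC(=O)[C@]3(OS(C)(=O)=O)[C@H]2O)c(=O)[nH]c1=O` reaches only a limit of this assay, >= 250000 nM, shown as the limit of >= 250000 nM in this assay, at which 1 of the 3 values shown sits.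

Compound 4 `C=C(C)C(=O)NC(=O)NC1=CS(=O)(=O)O[C@@]12[C@@H](CO[Si](C)(C)C(C)(C)C)O[C@@H](n1cc(C)c(=O)n(C)c1=O)[C@@H]2O[Si](C)(C)C(C)(C)C` has not been measured. Against compound 1 it differs in one place: ((1-methylethenyl)carbonyl)carbamoyl in place of 2-carboxyethyl on an amine nitrogen. Among the compounds with values here, no measured pair shows the effect of such a change, so the size of the step is uncertain. Compound 4 is expected to be tolerated somewhat less, a modest step of a 1.9-fold lower number from compound 1 to compound 4 (0.28 log units; within the scatter) in this assay. The estimated value for compound 4 is 6000 nM, with a range from 1500 nM to 25000 nM.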

Compound 4, half-maximal cytotoxic concentration: 1190 nM
Compound 4: the middle estimate sits 5.0-fold (0.70 log units) above what was measured; the whole stated range lies above it.
By their numbers in this assay, from the lowest: compound 4; then compound 1; then compound 3. At a limit, above all of these: compound 2.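

In this assay, the group on this amine nitrogen clearly affects how much compound is tolerated: replacing 2-carboxyethyl with ((1-methylethenyl)carbonyl)carbamoyl gives a 9.7-fold lower number from compound 1 to compound 4 (0.99 log units; beyond the scatter). Within the data shown here, this is the first single change that can be read, as the earlier compounds offered no pair differing in one place. Nothing measured here explains the step.

On these data alone, it remains open whether the step follows from losing the carboxylic acid or from gaining the new group. An unsubstituted amine, an acetyl group or a longer chain on this nitrogen could help separate the two.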